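A Chloro Substituent Carried From One Core to Another

The source may report more compounds than this note shows. Statements on the series, on what has been measured and on what is new or still open speak of the compounds shown alone.

Three compounds have been measured in a functional assay on U-87MG ATCC cells for antiproliferative activity against U-87 MG (Homo sapiens), read by MTT assay, with a stated time of 48 h, tested at 50 uM; on this read-out higher numbers stand for a weaker effect at the one concentration tested and lower numbers for a stronger effect:

Compound 1, `Cc1nc(-c2ccccc2)sc1C(=O)CSc1nc(N)c(C#N)c(-c2ccc(Cl)cc2)n1`: 44.3%
Compound 2, `Cc1nc(-c2ccc(Cl)cc2)sc1C(=O)CSc1nc(N)c(C#N)c(-c2ccc(Cl)cc2)n1`: 15.5%
Compound 3, `COc1ccc(-c2nc(C)c(C(=O)CSc3nc(-c4ccccc4)c(C#N)c(=O)[nH]3)s2)cc1`: 72.5%

Compound 1 and compound 2 share a core; the change chloro in place of hydrogen on an aromatic carbon made a number 28.8 percentage points lower from compound 1 to compound 2 (beyond the scatter). Compound 3 gives the highest of the three numbers, and the difference between its core and that of compound 1 is not broken down here.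

Compound 4, `COc1ccc(-c2nc(C)c(C(=O)CSc3nc(-c4cccc(Cl)c4)c(C#N)c(=O)[nH]3)s2)cc1`, is not yet measured in this assay. It differs from compound 3 by chloro in place of hydrogen on an aromatic carbon. This is the same kind of change as that from compound 1 to compound 2, but not the same: there the chloro stands para to a large group, here meta to a large group, and the cores differ. Within the data shown here, with only one earlier example, on another core and at another place, the step for compound 4 is expected to be a number 17.5 percentage points lower from compound 3 to compound 4 (beyond the scatter), resting on a number 28.8 percentage points lower from compound 1 to compound 2 (beyond the scatter) but taken as smaller and less certain. Compound 4 is therefore estimated at 55%, expected between 35% and 75%.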

Compound 4, a percentage reported as activity, at one concentration (the size of the read-out at that concentration, not a potency): 83.4%
Beside the measured number, compound 4's estimate is 28.4 percentage points below it; the whole stated range lies below it.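

In this assay, the change from phenyl to 3-chlorophenyl gives a number 10.9 percentage points higher from compound 3 to compound 4 (beyond the scatter), so on this core the added chloro goes with a weaker effect at the one concentration tested. Set beside the earlier step, the same kind of change does not carry over from one core to the other, even in direction: the same change on two cores in this assay, a number 28.8 percentage points lower (beyond the scatter) from compound 1 to compound 2 and a number 10.9 percentage points higher (beyond the scatter) from compound 3 to compound 4, 39.7 percentage points apart, beyond the scatter of two such steps This does not show what sets the two steps apart, since the two pairs differ both in their core and in where the chloro stands, and one pair on each core gives no rule for the series.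

From the compounds shown here alone, it remains open whether a chloro in the place it holds in compound 2 would lower the number on the core of compound 3, which would separate the role of the place from that of the core. Also open, going by these compounds, is what a fluoro or a bromo in place of the chloro of compound 4 would give in this assay.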